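The source may report more compounds than this note shows. Statements on the series, on what has been measured and on what is new or still open speak of the compounds shown alone.

Compound 1 `O=[N+]([O-])c1ccc(CN2CCC(n3cc(CC(OCc4cc(-c5ccccc5)no4)c4ccc(Br)cc4)nn3)CC2)cc1` gives 3000 nM in a functional assay on MDA-MB-468 cells (Homo sapiens) for cytotoxicity, with a stated time of 48 h (a lower number here means a stronger inhibitor, a higher number a weaker inhibitor), the lowest of the two numbers recorded here. Compound 2 `COc1ccc(-c2cc(COC(Cc3cn(C4CCN(Cc5ccc([N+](=O)[O-])cc5)CC4)nn3)c3ccc(Br)cc3)on2)cc1`, which carries methoxy in place of hydrogen on an aromatic carbon, gives 9000 nM, so the step of a 3.0-fold higher number from compound 1 to compound 2 (0.48 log units; beyond the scatter) is a modest weakening. Compound 3 `N#Cc1cccc(-c2cc(COC(Cc3cn(C4CCN(Cc5ccc([N+](=O)[O-])cc5)CC4)nn3)c3ccc(Br)cc3)on2)c1`, with cyano in place of hydrogen on an aromatic carbon, reports only > 25000 nM, which is a limit of the assay rather than a number. That value is the limit of > 25000 nM in this assay, at which 1 of the 3 values shown sits. The step of an at least 8.3-fold higher number from compound 1 to compound 3 (0.92 log units; beyond the scatter) is therefore at least modest, and an at least 2.7-fold higher number from compound 2 to compound 3 (0.44 log units; beyond the scatter) also points toward weaker inhibition.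

Compound 4 `O=[N+]([O-])c1ccc(CN2CCC(n3cc(CC(OCc4cc(-c5ccccc5F)no4)c4ccc(Br)cc4)nn3)CC2)cc1` differs from compound 1 by fluoro in place of hydrogen on an aromatic carbon. Both recorded changes on this phenyl weakened inhibition, while the entering fluoro is a single heavy atom with no hydrogen-bond donors or acceptors. A weakening of similar or smaller size is therefore expected in this assay, possibly not beyond the scatter. Compound 4 is expected to give about 4500 nM, between 1500 nM and 13000 nM, a step of a 1.5-fold higher number from compound 1 to compound 4 (0.18 log units; within the scatter).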

Compound 4, half-maximal inhibitory concentration: 4000 nM
Compound 4: middle estimate off by 1.1-fold (0.05 log units), on the high side; the measured number falls inside the stated range.
By their numbers in this assay, from the lowest: compounds 1 and 4 (each within the scatter of the next); then compound 2. At a limit, above all of these: compound 3.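

On this phenyl, a substituent ortho to a large group can be carried without a change beyond the scatter, which neither earlier substituent showed: the step of a 1.3-fold higher number from compound 1 to compound 4 (0.12 log units; within the scatter) stays small. The 2-fluorophenyl compound also separates from the two other substituted compounds, with the steps of a 2.3-fold lower number from compound 2 to compound 4 (0.35 log units; beyond the scatter) and an at least 6.2-fold lower number from compound 3 to compound 4 (0.79 log units; beyond the scatter) showing that a substituent on this phenyl need not cost as much as 4-methoxyphenyl or 3-cyanophenyl. Compound 3 reports a limit of the assay rather than a number: the limit of > 25000 nM in this assay, at which 1 of the 4 values shown sits.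

The 4-methoxyphenyl, 3-cyanophenyl and 2-fluorophenyl names each place their group differently on the ring, so the group and its place cannot be told apart. Going by these compounds, it remains open whether fluoro elsewhere on this phenyl, or an amine or a carboxylic acid at this place, would give a similar number.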